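The source may report more compounds than this note shows. Statements on the series, on what has been measured and on what is new or still open speak of the compounds shown alone.

Measured so far in a functional assay on cells for agonist activity at 5-hydroxytryptamine receptor 7 (Homo sapiens), read by a luciferase reporter and beta-arrestin recruitment, with a stated time of 22 h; a higher number here means a larger maximal response, a lower number a smaller maximal response:

compound 1 `Fc1ccc(-c2noc3c2CCNCC3)cc1`: 38.2%
compound 2 `Fc1ccc(-c2n[nH]c3c2CCNCC3)cc1`: 53.9%
compound 3 `Clc1ccc(-c2noc3c2CCNCC3)cc1`: 47.1%

In this assay, among the measured compounds shown here, the only single-point change measured is chloro in place of fluoro on an aromatic carbon, which gives a number 8.9 percentage points higher from compound 1 to compound 3 (within the scatter). Compound 2 carries a different core from compound 1; the difference between the two cores is not broken down here. The value of compound 2 stands beyond the scatter from that of compound 1, but within the scatter of compound 3.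

Compound 4 `Clc1ccc(-c2n[nH]c3c2CCNCC3)cc1` is not yet measured. It relates to compound 2 by chloro in place of fluoro on an aromatic carbon, the same change that leads from compound 1 to compound 3. Because a number 8.9 percentage points higher from compound 1 to compound 3 (within the scatter) stayed within the scatter, the expected step is also a small one, a number 6.1 percentage points higher from compound 2 to compound 4 (within the scatter). Compound 4 is therefore estimated at 60% in this assay, with a likely range from 48% to 72%.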

Compound 4, largest response reached (Emax), in percent of the reference or control that the assay uses: 62.8%
For compound 4 the middle estimate is 2.8 percentage points below the measured one; the range from low to high includes it.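

In this assay, chloro in place of fluoro on an aromatic carbon gives a number 8.9 percentage points higher from compound 2 to compound 4 (within the scatter), and the same change on the other core gives a matching step: the same change on two cores in this assay, a number 8.9 percentage points higher (within the scatter) from compound 1 to compound 3 and a number 8.9 percentage points higher (within the scatter) from compound 2 to compound 4, 0 percentage points apart, within the scatter of two such steps

On these two cores, the change carries over with no sign that the core alters its size. Each step alone stays within the scatter, however, so a real effect of the change on the maximal response is not shown, and two cores set no rule for a third.

The compounds shown hold only fluoro and chloro at this place. As far as these compounds go, how bromo, methoxy or an amine there would behave on either core stays open.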